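Three amide substituents on one shared core

The source may report more compounds than this note shows. Statements on the series, on what has been measured and on what is new or still open speak of the compounds shown alone.

Measured compounds in a functional assay on PC-3 cells (Homo sapiens) for antiproliferative activity, read by MTT assay, with a stated time of 24 h; a higher number here means a weaker inhibitor, a lower number a stronger inhibitor:
- compound 1 `CCn1c(C(=O)NCCNC(=O)OC(C)(C)C)ccc1C(CC)(CC)c1ccc(OCS(=O)(=O)c2ccccc2)c(C)c1` gives > 50000 nM, which is a limit of the assay and not a number
- compound 2 `CCn1c(C(=O)NCCO)ccc1C(CC)(CC)c1ccc(OCS(=O)(=O)c2ccccc2)c(C)c1` gives 17700 nM
- compound 3 `CCn1c(C(=O)NC2(CO)CC2)ccc1C(CC)(CC)c1ccc(OCS(=O)(=O)c2ccccc2)c(C)c1` gives 3560 nM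

Compound 1 stands at the top of the numbers shown: its value is only a limit, so its true number is not known (the limit of > 50000 nM in this assay, at which 1 of the 3 values shown sits). Compound 4 `CCn1c(C(=O)N[C@@H](C(=O)O)C(C)C)ccc1C(CC)(CC)c1ccc(OCS(=O)(=O)c2ccccc2)c(C)c1` differs from compound 1 in one place: 1-carboxy-2-methylpropyl in place of 2-((tert-butoxycarbonyl)amino)ethyl on an amide-type nitrogen. Two measured steps start from compound 1 and both swap the same group for something smaller. The step of an at least 2.8-fold lower number from compound 1 to compound 2 (0.45 log units; beyond the scatter) and the step of an at least 14-fold lower number from compound 1 to compound 3 (1.14 log units; beyond the scatter) both moved the number downward, and between those two, a 5.0-fold lower number from compound 2 to compound 3 (0.70 log units; beyond the scatter). Since compound 4 also carries a smaller group on the amide-type nitrogen, a downward step in this assay is expected, of about an at least 4.1-fold lower number from compound 1 to compound 4 (0.61 log units; beyond the scatter), though because compound 1 sits at a limit of > 50000 nM in this assay, at which 1 of the 3 values shown sits, the size is uncertain. Compound 4 is therefore estimated at 12000 nM, between 3000 nM and 50000 nM.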

Compound 4, half-maximal inhibitory concentration: 3070 nM
Compound 4: the middle estimate sits 3.9-fold (0.59 log units) above what was measured, within the range that was stated.
By their numbers in this assay, from the lowest: compounds 4 and 3 (each within the scatter of the next); then compound 2. At a limit, above all of these: compound 1.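

Compound 4 shows that this amide-type nitrogen can carry a group ending in a carboxy group, 1-carboxy-2-methylpropyl, and give a number that cannot be told apart from that of the hydroxy-bearing 1-(hydroxymethyl)cyclopropyl group: a 1.2-fold lower number from compound 3 to compound 4 (0.06 log units; within the scatter). Measured against the simpler 2-hydroxyethyl group, the same change gives a 5.8-fold lower number from compound 2 to compound 4 (0.76 log units; beyond the scatter). Against 2-((tert-butoxycarbonyl)amino)ethyl the step is an at least 16-fold lower number from compound 1 to compound 4 (1.21 log units; beyond the scatter), but compound 1 has only a limit, so the true size of this step stays unknown: the limit of > 50000 nM in this assay, at which 1 of the 4 values shown sits.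

The compounds shown do not separate the part played by the carboxy group from that of the rest of 1-carboxy-2-methylpropyl, including its defined stereocentre. As far as these compounds go, how a free amine, a methyl ester of the acid or a longer chain on this nitrogen would read in this assay remains open.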